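Swapping a Chain for an Aryl Linker

The source may hold more compounds than are shown below. What is called first, only, known or untested is meant among the compounds shown, and "the series" means these compounds.

Compound 1 `Cn1cc(-c2ccccc2Oc2ccccc2)c2cc(C(=O)NCCCCCCC(=O)NO)[nH]c2c1=O` and compound 3 `Cn1cc(-c2ccccc2Oc2ccccc2)c2cc(C(=O)NCc3ccc(C(=O)NO)cc3)[nH]c2c1=O` share one core and differ in a single place: 4-(hydroxycarbamoyl)phenyl in place of 5-(hydroxycarbamoyl)pentyl on a saturated chain carbon bound to an amide-type nitrogen. In a functional assay on MV4-11 cells (Homo sapiens) for antiproliferative activity, read by CCK-8 assay, with a stated time of 72 h (on this read-out higher numbers stand for weaker inhibition and lower numbers for stronger inhibition), compound 1 gives 180 nM, whereas compound 3 gives 570 nM, so the step is a 3.2-fold higher number from compound 1 to compound 3 (0.50 log units; beyond the scatter). Compound 2 `Cn1cc(-c2cc(C(C)(C)O)ccc2OC2CC2)c2cc(C(=O)NCCCCCCC(=O)NO)[nH]c2c1=O` is built on another core; how that core differs from the core of compound 1 is not broken down here. In this assay compound 2 gives 220 nM. Compound 4 `Cn1cc(-c2cc(C(C)(C)O)ccc2OC2CC2)c2cc(C(=O)NCc3ccc(C(=O)NO)cc3)[nH]c2c1=O` is not yet measured and stands to compound 2 exactly as compound 3 stands to compound 1, through the same change: 4-(hydroxycarbamoyl)phenyl in place of 5-(hydroxycarbamoyl)pentyl on a saturated chain carbon bound to an amide-type nitrogen. The starting points are close, since compound 1 gives 180 nM and compound 2 gives 220 nM. A step of similar size is therefore expected, estimated as a 3.1-fold higher number from compound 2 to compound 4 (0.49 log units; beyond the scatter). In this assay compound 4 is expected to give about 680 nM, plausibly between 350 nM and 1400 nM.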

Compound 4, half-maximal inhibitory concentration: 420 nM
For compound 4 the middle estimate is 1.6-fold (0.21 log units) above the measured one, and the stated range covers the measured number.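

Moved to the core of compound 2, the swap of 5-(hydroxycarbamoyl)pentyl for 4-(hydroxycarbamoyl)phenyl gives a 1.9-fold higher number from compound 2 to compound 4 (0.28 log units; within the scatter) in this assay and so, unlike the step on the core of compound 1, stays inside the usual scatter. This does not prove that the swap weakens inhibition on every core, and two cores cannot show how it would behave on a third. Still, the two steps cannot be told apart, so the change carries over from one core to the other as far as these two pairs can show: the same change on two cores in this assay, a 3.2-fold higher number (0.50 log units; beyond the scatter) from compound 1 to compound 3 and a 1.9-fold higher number (0.28 log units; within the scatter) from compound 2 to compound 4, 1.7-fold (0.22 log units) apart, within the scatter of two such steps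

The compounds shown leave open how a longer chain would compare with these two linkers. They also leave open what a carboxylic acid would do in place of the hydroxycarbamoyl group.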